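Ethyl to isopropyl on a piperidine amine

This account rests on a few compounds, and the source may have more. Where it says the series, first, only, none or still open, it means among the compounds named here.

Measured so far:
- compound 1, `Clc1ccc(Oc2ccc3nc(-c4ccc(OCC5CCNCC5)cc4)oc3c2)cc1`, in an assay on isolated protein for inhibition of advanced glycosylation end product-specific receptor (Homo sapiens), read by FRET, with stated times of 30 min and 1 h, tested at 4 uM (on this read-out lower numbers stand for less inhibition and higher numbers for more inhibition at the one concentration tested (going by the name of the read-out)), gives "not active" (no number reported)
- compound 2, `CCN1CCC(Oc2ccc(-c3nc4ccc(Oc5ccc(Cl)cc5)cc4o3)cc2)CC1`, in this assay gives 15.3%

Compound 1 in this assay came out as "not active" (no number reported), so no number is reported for it. Among the measured compounds shown here, compound 2 in this assay is therefore the only entry with a number, 15.3%, and there is nothing else with a number to compare it against. For the measured compounds named here, the two values show only that compound 2 gives a modest reading where compound 1 gives none.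

The next compound, compound 3, `CC(C)N1CCC(Oc2ccc(-c3nc4ccc(Oc5ccc(Cl)cc5)cc4o3)cc2)CC1`, differs from compound 2 in one place: methyl in place of hydrogen on a saturated chain carbon bound to an amine nitrogen in a ring and a saturated chain carbon. Going by the values given here, no measured pair with a comparable change exists here, so the size of the step can only be guessed. A single methyl added on that chain carbon is a small change, and the expectation is a step of a number 0.3 percentage points lower from compound 2 to compound 3 (within the scatter) in this assay, that is, none beyond the scatter. The estimate for compound 3 in this assay is 15%, with a likely range from 0% to 35%.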

Compound 3, a percentage reported as inhibition, at one concentration (the size of the read-out at that concentration, not a potency): 12.7%
Beside the measured number, compound 3's estimate is 2.3 percentage points above it; the measured number falls inside the stated range.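

In this assay, the change from 1-ethylpiperidin-4-yl to 1-isopropylpiperidin-4-yl gives a number 2.6 percentage points lower from compound 2 to compound 3 (within the scatter), so a methyl added at this chain carbon does not move the reading by more than repeated measurements normally would. Among the compounds shown here, until now this position had only one number attached to it, and this pair gives the first direct view of what a change there does, though it covers only one small step and a single tested concentration. Nothing shown here bears on why the two readings stay so close.

The compounds shown leave open whether a larger group on the ring amine nitrogen, such as benzyl or cyclohexyl, or a chain ending in a carboxylic acid, would shift the reading beyond the usual scatter. They also leave open what the unsubstituted amine would give on this same oxygen-linked piperidine, since compound 1 differs from these compounds in more than one place and its result cannot be set against this step.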